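Swapping a Fluorophenyl for a Pyridinyl Ether

This account rests on a few compounds, and the source may have more. Where it says the series, first, only, none or still open, it means among the compounds named here.

Compound 1 (`COC1=CC(=O)c2c(COc3ccc(N)cc3)c(C)n(C)c2C1=O`): 160 nM
Compound 2 (`COC1=CC(=O)c2c(COc3ccc(C(F)(F)F)cc3)c(C)n(C)c2C1=O`): 311 nM
Compound 3 (`COC1=CC(=O)c2c(COc3ccc(F)cc3)c(C)n(C)c2C1=O`): 493 nM

All three values come from a functional assay on MIA PaCa-2 cells (Homo sapiens) for cytotoxicity, read by MTT assay, with a stated time of 72 h; on this read-out lower numbers stand for stronger inhibition and higher numbers for weaker inhibition. The standing of compound 3 rests on two steps: a 3.1-fold higher number from compound 1 to compound 3 (0.49 log units; beyond the scatter) and a 1.6-fold higher number from compound 2 to compound 3 (0.20 log units; within the scatter). It is therefore clearly separated only from compound 1.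

Compound 4 (`COC1=CC(=O)c2c(COc3ccncc3)c(C)n(C)c2C1=O`) departs from compound 3 in one place (pyridin-4-yl in place of 4-fluorophenyl on an oxygen on a saturated carbon): pyridin-4-yl in place of 4-fluorophenyl on an oxygen on a saturated carbon. Among the compounds with values here, no measured step makes this ring change. The closest evidence is the three swaps of one group for another on an aromatic carbon, which include a 1.9-fold higher number from compound 1 to compound 2 (0.29 log units; within the scatter) and which reach only a modest size at most. On that basis, no step beyond the scatter is expected in this assay, and the data give no firm direction. The estimated step is a 1.4-fold lower number from compound 3 to compound 4 (0.15 log units; within the scatter). For compound 4 the expected value is 350 nM with an estimated range from 120 nM to 1000 nM.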

Compound 4, half-maximal inhibitory concentration: 3270 nM
Compound 4: the middle estimate sits 9.3-fold (0.97 log units) below what was measured; measured number outside the range, above it.
By their numbers in this assay, from the lowest: compounds 1, 2 and 3 (each within the scatter of the next, the first and the last beyond it); then compound 4.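

Putting pyridin-4-yl in place of 4-fluorophenyl on the oxygen gives a 6.6-fold higher number from compound 3 to compound 4 (0.82 log units; beyond the scatter) in this assay, so exchanging the ring itself at this position moved the number further than any of the three substituent swaps on the aromatic carbon had. Measured against the 4-aminophenyl ether, the same ring gives a 20-fold higher number from compound 1 to compound 4 (1.31 log units; beyond the scatter) and this is the widest gap among the compounds shown. The data include no measurement that accounts for this change.

The compounds shown leave open whether the step belongs to the ring nitrogen alone, since an unsubstituted phenyl ether would separate that from the loss of the fluorine. They also leave open whether a pyridin-4-yl ring carrying an amino group, or a pyrimidine ring, would regain the lower numbers.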